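The source may report more compounds than this note shows. Statements on the series, on what has been measured and on what is new or still open speak of the compounds shown alone.

Measured compounds:

Compound 1 `CNC(=O)CSc1nc2ccc(NC(=O)c3ccccc3OC)cc2s1` — 23400 nM in a functional assay on MCF7 cells (Homo sapiens) for cytotoxicity, read by MTT assay, with a stated time of 48 h; a higher number here means a weaker inhibitor, a lower number a stronger inhibitor
Compound 2 `CNC(=O)CSc1nc2ccc(NC(=O)c3ccc([N+](=O)[O-])cc3)cc2s1` — > 100000 nM in this assay
Compound 3 `O=C(CSc1nc2ccc(NC(=O)c3ccc([N+](=O)[O-])cc3)cc2s1)NCc1ccccc1` — > 100000 nM in this assay

The three compounds share one core and differ at two places. The value for compound 2 is a limit of this assay and not a number. The value for compound 3 is likewise a limit. Both sit at the limit of > 100000 nM in this assay, at which 2 of the 3 values shown sit, so only compound 1 carries a measured number.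

Compound 2 and compound 1 differ by 2-methoxyphenyl in place of 4-nitrophenyl on a carbonyl carbon. That change gives an at least 4.2-fold lower number from compound 2 to compound 1 (0.63 log units; beyond the scatter). Compound 2 and compound 3 differ in the core by phenyl in place of hydrogen on a saturated chain carbon bound to an amide-type nitrogen; here a step that the two limits leave unreadable from compound 2 to compound 3, since both values are limits.

Compound 4 `COc1ccccc1C(=O)Nc1ccc2nc(SCC(=O)NCc3ccccc3)sc2c1` has not yet been measured. It differs from compound 3 by 2-methoxyphenyl in place of 4-nitrophenyl on a carbonyl carbon, the same change that turned compound 2 into compound 1, at a place described in the same words in both cases. The cores of compound 3 and compound 4 carry the benzylcarbamoyl group in place of the methylcarbamoyl group of compound 1 and compound 2.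

The expectation rests on compound 1 with 23400 nM and on the step of an at least 4.2-fold lower number from compound 2 to compound 1 (0.63 log units; beyond the scatter), which the same change produced there. The step from compound 3 to compound 4 is expected to be an at least 4.0-fold lower number from compound 3 to compound 4 (0.60 log units; beyond the scatter). Compound 4 is therefore estimated at 25000 nM in this assay, most likely between 8000 nM and 100000 nM.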

Compound 4, half-maximal inhibitory concentration: 17200 nM
Compound 4: the middle estimate sits 1.5-fold (0.16 log units) above what was measured; measured number inside the range.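

In this assay, 2-methoxyphenyl in place of 4-nitrophenyl on a carbonyl carbon gives an at least 5.8-fold lower number from compound 3 to compound 4 (0.76 log units; beyond the scatter), so the change lowers the number on both cores, and its direction carries over in these two pairs: the same change on two cores in this assay, an at least 4.2-fold lower number (0.63 log units; beyond the scatter) from compound 2 to compound 1 and an at least 5.8-fold lower number (0.76 log units; beyond the scatter) from compound 3 to compound 4; the limit leaves it open whether they differ It does not show that the size carries over, since each step starts from a limit and not from a number, which bounds the step on one side only: the limit of > 100000 nM in this assay, at which 2 of the 4 values shown sit. With 2-methoxyphenyl in place, the other change, phenyl in place of hydrogen on a saturated chain carbon bound to an amide-type nitrogen, gives a 1.4-fold lower number from compound 1 to compound 4 (0.13 log units; within the scatter), while the matching step between the two 4-nitrophenyl compounds cannot be read.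

The compounds shown leave open where the two 4-nitrophenyl compounds would fall as measured numbers, and so whether the change is larger on one core than on the other. They also leave open how an amine or a carboxylic acid in place of the methoxy group, or a longer chain in place of the benzylcarbamoyl group, would read in this assay.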